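Sulfonamide-linked triazoles: a chlorophenyl swap on the ring nitrogen

The source may report more compounds than this note shows. Statements on the series, on what has been measured and on what is new or still open speak of the compounds shown alone.

Measured compounds:
- compound 1, `O=c1[nH]cc(S(=O)(=O)Nc2ccccc2-c2cn(-c3ccc(Cl)cc3)nn2)c(=O)[nH]1`: 1180 nM
- compound 2, `O=c1[nH]cc(S(=O)(=O)Nc2cccc(-c3cn(-c4cccc(Cl)c4)nn3)c2)c(=O)[nH]1`: 2430 nM
- compound 3, `Cc1ccc(-n2cc(-c3ccc(NS(=O)(=O)c4c[nH]c(=O)[nH]c4=O)cc3)nn2)cc1`: 5560 nM

The three measured compounds share a core and were tested in a functional assay on A549 cells (Homo sapiens) for antiproliferative activity, read by MTT assay, with a stated time of 24 h; a higher number here means a weaker inhibitor, a lower number a stronger inhibitor. Compound 3 stands highest of the three numbers. Its nearest neighbour is compound 2, whose number is lower by a margin beyond the scatter, and compound 1 lies furthest, lower still. Compounds 1 and 2 each differ from compound 3 in more than one place, so no single change can be read from these pairs.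

Compound 4, `O=c1[nH]cc(S(=O)(=O)Nc2ccc(-c3cn(-c4cccc(Cl)c4)nn3)cc2)c(=O)[nH]1`, has not yet been measured. It differs from compound 3 by 3-chlorophenyl in place of 4-methylphenyl on an aromatic nitrogen, in words: 3-chlorophenyl in place of 4-methylphenyl on an aromatic nitrogen. Among the measured compounds shown here, no step between measured compounds isolates this change. The two chlorophenyl compounds, compound 1 and compound 2, both show lower numbers than compound 3, but their attachment to the core also differs, so that evidence is indirect. A modest step toward a lower number, possibly within the scatter, seems the most reasonable expectation.

Compound 4 is estimated at 3500 nM, with a range from 1500 nM to 9000 nM. The expected step of a 1.6-fold lower number from compound 3 to compound 4 (0.20 log units; within the scatter) is small and downward.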

Compound 4, half-maximal inhibitory concentration: 2310 nM
For compound 4 the middle estimate is 1.5-fold (0.18 log units) above the measured one, and the stated range covers the measured number.
By their numbers in this assay, from the lowest: compounds 1, 4 and 2 (each within the scatter of the next, the first and the last beyond it); then compound 3.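

Among the compounds shown here, the comparison of compound 3 with compound 4 gives the first reading of a single change in this assay, with a 2.4-fold lower number from compound 3 to compound 4 (0.38 log units; beyond the scatter), so the group on this aromatic nitrogen of the triazole-type five-membered ring does bear on the number, if modestly. The two groups match in heavy-atom count, in having one six-membered aromatic ring of carbon only, and in having no hydrogen-bond donors or acceptors, so the step arises from a swap that leaves those counts untouched; it replaces the methyl with a chlorine and also moves the substituent around the phenyl ring, and this one step cannot tell those two parts apart. Nothing measured here accounts for the step, and no cause can be given for it.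

On these data alone, what remains open is whether the atom or its place on the phenyl ring carries the step, a question that 3-methylphenyl on the same nitrogen would address. Whether the number keeps moving with other groups here, such as unsubstituted phenyl or a phenyl ring bearing an amine or a carboxylic acid, also remains unanswered.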